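This account rests on a few compounds, and the source may have more. Where it says the series, first, only, none or still open, it means among the compounds named here.

The measured compounds:
Compound 1 `COc1ccc(CN(CC#N)Cc2ccccc2)cc1` gives 0% in an assay on HEK293 cells for binding affinity to Substance-K receptor (Rattus norvegicus), read by FRET, tested at 10 uM; a lower number here means less inhibition, a higher number more inhibition at the concentration tested (going by the name of the read-out).
Compound 2 `CCOC(=O)CCCCN(Cc1ccccc1)Cc1ccc2ccccc2c1` gives 0%.
Compound 3 `CCCCCCCCCCCCCCCCOC(=O)CN(Cc1ccccc1)Cc1ccc2ccccc2c1` gives 0%.

Compound 2 stands level with compounds 1 and 3 at the digits shown, within the scatter of repeated measurements; none of the three shows inhibition in this assay. Compound 4 `c1ccc(CN(Cc2ccc3ccccc3c2)c2ccncn2)cc1` has not yet been measured. It differs from compound 2 in one place: pyrimidin-4-yl in place of 4-(ethoxycarbonyl)butyl on an amine nitrogen. Among the measured compounds shown here, no step between measured compounds exists to guide the expectation, and the three measured compounds offer no spread to learn from. Because compound 2 gives 0% and compounds 1 and 3 sit at the same level, there is no basis for expecting a rise. The step is expected to be a number 5 percentage points higher from compound 2 to compound 4 (within the scatter), none beyond the scatter. Compound 4 is estimated at 5%, with a range from 0% to 20%.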

Compound 4, a percentage reported as inhibition, at one concentration (the size of the read-out at that concentration, not a potency): 34%
The estimate for compound 4 lay 29 percentage points below the measured number; measured number outside the range, above it.
By their numbers in this assay, from the lowest: compounds 1, 2 and 3 (each within the scatter of the next); then compound 4.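

In this assay, pyrimidin-4-yl in place of 4-(ethoxycarbonyl)butyl on an amine nitrogen gives a number 34 percentage points higher from compound 2 to compound 4 (beyond the scatter), the first sign that this position can change the read-out at all. Among the compounds shown here, the single step does not extend to any other change on the shared core. Nothing measured here explains the rise.

The compounds shown leave open whether the aromatic ring alone is enough or its ring nitrogens are needed, a question that a phenyl or a pyridin-4-yl group on the same amine nitrogen would address. They also leave open how potent compound 4 is, since its reading comes from one concentration.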